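The source may hold more compounds than are shown below. What is called first, only, known or untested is meant among the compounds shown, and "the series" means these compounds.

The shared core carries two hydroxyls in compound 2 `Oc1ccc(/C=C/c2ccc(/C=C/c3ccc(O)cc3)c(C(F)(F)F)c2)cc1` and compound 3 `Oc1ccc(/C=C/c2ccc(/C=C/c3ccc(O)cc3)c(OCC(F)(F)F)c2)cc1`, while compound 1 `COc1cc(/C=C/c2ccc(C(F)(F)C(F)F)cc2)ccc1/C=C/c1ccc(C(F)(F)C(F)F)cc1` carries a methoxy and two tetrafluoroethyl groups instead. In a physicochemical assay for lipophilicity, read by HPLC (on this read-out lower numbers stand for lower lipophilicity and higher numbers for higher lipophilicity), compound 1 gives > 7, which is a limit of the assay rather than a number (the limit of > 7 in this assay, at which 1 of the 3 values shown sits). Compound 2 gives 5.64 in this assay. Compound 3 gives 5.25 and so holds the lowest of the two numbers, compound 2 being its nearest neighbour, with the step of a number 0.39 log units lower from compound 2 to compound 3 (beyond the scatter). Compound 4 `Oc1ccc(/C=C/c2ccc(/C=C/c3ccc(O)cc3)c(OCCCC(F)(F)F)c2)cc1` differs from compound 3 by 3,3,3-trifluoropropyl in place of trifluoromethyl on a saturated chain carbon bound to an oxygen on an aromatic ring. Among the measured compounds shown here, no measured step covers a lengthening of this kind: the step from compound 2 to compound 3 swaps one group for another, and the limit of compound 1 gives no number to build on. The added chain is nevertheless expected to raise the read-out in this assay, and for compound 4 the expected step is a number 0.90 log units higher from compound 3 to compound 4 (beyond the scatter), beyond the scatter. Compound 4 is therefore estimated at 6.15, with a range from 5.6 to 6.7.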

Compound 4, partition coefficient: 5.79
Compound 4: middle estimate off by 0.36 log units, on the high side; low and high end bracket the measured number.
By their numbers in this assay, from the lowest: compound 3; then compounds 2 and 4 (each within the scatter of the next). At a limit, above all of these: compound 1.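

In this assay, the series now has a measured lengthening at this position, with 3,3,3-trifluoropropyl in place of trifluoromethyl on a saturated chain carbon bound to an oxygen on an aromatic ring giving a number 0.54 log units higher from compound 3 to compound 4 (beyond the scatter) as a modest step. Among the compounds shown here, earlier, the only measured change at this place was the swap of trifluoromethyl for 2,2,2-trifluoroethoxy on an aromatic carbon, which lowered the number. With 4,4,4-trifluorobutoxy in that place, the comparison gives a number 0.15 log units higher from compound 2 to compound 4 (within the scatter) and the two groups cannot be told apart on this read-out.

On these data alone, whether a longer chain on the same oxygen, or an amine at the end of the chain, would shift the read-out in this assay stays open. Nothing measured in this series bears on the reason for these steps.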